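Swapping the halophenyl group on a cinnamoyl anilide scaffold

The source may hold more compounds than are shown below. What is called first, only, known or untested is meant among the compounds shown, and "the series" means these compounds.

Of the compounds shown here, two have been tested in a functional assay on SMMC-7721 cells (Homo sapiens) for cytotoxicity, read by MTT assay, with a stated time of 72 h; a lower number here means a stronger inhibitor, a higher number a weaker inhibitor. Compound 1, `O=C(CCl)Nc1ccc(C(=O)/C=C/c2ccccc2Cl)cc1`, gives 11100 nM in this assay. Compound 2, `O=C(CSC(=S)N[C@H]1CCOC1=O)Nc1ccc(C(=O)/C=C/c2ccc(F)cc2)cc1`, carries a dithiocarbamate side chain together with a 4-fluorophenyl group on the chain. For compound 2 this assay reports only a limit, > 128000 nM, so its true value is not known as a number. The limit itself, (the limit of > 128000 nM in this assay, at which 1 of the 2 values shown sits), marks the edge of what this assay can resolve, and compound 2 sits at that edge. Compound 1 and compound 2 differ in more than one place, so their two values are not read here as a single step.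

Compound 3, `O=C(CSC(=S)N[C@H]1CCOC1=O)Nc1ccc(C(=O)/C=C/c2ccccc2Cl)cc1`, is the next member. It differs from compound 2 by 2-chlorophenyl in place of 4-fluorophenyl on a double-bonded chain carbon bound to a double-bonded chain carbon. Among the measured compounds shown here, no measured step separates these two, so the effect of this swap can only be estimated. Compound 3 is expected to give 90000 nM, in a range from 15000 nM to 400000 nM. The expected step of an at least 1.4-fold lower number from compound 2 to compound 3 (0.15 log units; that floor lies within the scatter) is thus modest and uncertain, with a fair chance that this assay again reports only a limit.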

Compound 3, half-maximal inhibitory concentration: 20400 nM
For compound 3 the middle estimate is 4.4-fold (0.64 log units) above the measured one; low and high end bracket the measured number.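

In this assay, 2-chlorophenyl in place of 4-fluorophenyl on a double-bonded chain carbon bound to a double-bonded chain carbon gives an at least 6.2-fold lower number from compound 2 to compound 3 (0.79 log units; beyond the scatter), so a change at this place on the chain can be seen in the read-out. The value for compound 2 is a limit and not a number, so this step gives only a floor for the size of the change: the limit of > 128000 nM in this assay, at which 1 of the 3 values shown sits. With 2-chlorophenyl held fixed, the dithiocarbamate side chain in place of one chlorine atom, on a saturated chain carbon bound to a carbonyl carbon, gives a 1.8-fold higher number from compound 1 to compound 3 (0.26 log units; within the scatter), so the two compounds cannot be told apart and the side chain alone does not bring a compound to the limit.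

The halogen and its place on the ring change together in the swap, and a 4-chlorophenyl or a 2-fluorophenyl group carrying the same side chain would be needed to separate the two. From the compounds shown here alone, how an amine or a carboxylic acid would read at the place of the chlorine atom on the saturated chain carbon also remains open.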